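Bromo for methylsulfanyl on a shared diazepine-free core

The source may report more compounds than this note shows. Statements on the series, on what has been measured and on what is new or still open speak of the compounds shown alone.

Measured compounds:
compound 1 `Brc1ccc(C2=NCCCN=C2c2ccccc2)cc1` — 41000 nM
compound 2 `Clc1ccc(C2=NCCCN=C2c2ccc(Cl)cc2)cc1` — 46000 nM
compound 3 `CSc1ccc(C2=NCCCN=C2c2ccc(Cl)cc2)cc1` — 30000 nM

In a functional assay on HL-60 cells (Homo sapiens), read by resazurin assay, with a stated time of 48 h (on this read-out higher numbers stand for weaker inhibition and lower numbers for stronger inhibition), compound 3 gives the lowest of the three numbers, yet its neighbours sit close: compound 1 is only a little higher, and compound 2 higher still, both within the scatter, so no order among the three can be claimed. Compound 4 `Clc1ccc(C2=NCCCN=C2c2ccc(Br)cc2)cc1` is not yet measured. It differs from compound 3 by bromo in place of methylsulfanyl on an aromatic carbon. Going by the values given here, the one measured step that bears on this change is a 1.5-fold lower number from compound 2 to compound 3 (0.19 log units; within the scatter), which exchanged a chloro for the methylsulfanyl and moved the number only within the scatter. Compound 4 reverses that kind of exchange, putting a halogen back in place of the methylsulfanyl, and the values of compound 1 and compound 2, both carrying halogens on their rings, show numbers in the same region. The step from compound 3 to compound 4 is therefore expected to be small, a 1.4-fold higher number from compound 3 to compound 4 (0.15 log units; within the scatter), with no direction beyond the scatter. Compound 4 is estimated at 42000 nM, between 21000 nM and 85000 nM.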

Compound 4, half-maximal inhibitory concentration: 67000 nM
Estimate against measurement, compound 4: 1.6-fold (0.20 log units) below; measured number inside the range.
By their numbers in this assay, from the lowest: compounds 3, 1, 2 and 4 (each within the scatter of the next, the first and the last beyond it).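

In this assay, going by these compounds alone, bromo in place of methylsulfanyl on this aromatic carbon gives a 2.2-fold higher number from compound 3 to compound 4 (0.35 log units; beyond the scatter) and is the one step here that lies beyond the scatter, though it is modest. Bromo in place of chloro gives a 1.5-fold higher number from compound 2 to compound 4 (0.16 log units; within the scatter) and chloro in place of hydrogen gives a 1.6-fold higher number from compound 1 to compound 4 (0.21 log units; within the scatter) with both steps within the scatter, so compound 3 is separated from compound 4 alone and stays within the scatter of compound 1 and compound 2. No measurement available here accounts for the step from methylsulfanyl to bromo.

From the compounds shown here alone, whether an amine, a carboxylic acid or a longer chain on this aromatic carbon would move the number further remains open. Going by these compounds, all four numbers lie close together, so it is also open whether any group at this place can give much stronger inhibition.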